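The compounds below may be only part of what the source reports. "The series", "measured", "known", "first", "only" and "open" are said of these compounds alone.

In a physicochemical assay for lipophilicity, at pH 7.4 (a lower number here means a more polar compound, a higher number a more lipophilic compound), compound 1 `Cc1ccc(N(CC(C)C)S(=O)(=O)c2ccc3c(c2)C(=O)CC(C2CCOCC2)O3)c(C)c1` gives 4.28, compound 2 `CC(C)CN(c1ccc(F)cc1F)S(=O)(=O)c1ccc2c(c1)C(=O)CC(C1CCOCC1)O2` gives 3.62, and compound 3 `CC(C)CN(c1ccc(N(C)C)cc1)S(=O)(=O)c1ccc2c(c1)C(=O)CC(C1CCOCC1)O2` gives 3.6. Compound 3 holds the lowest of the three numbers: compound 2 lies within the scatter of it, while compound 1 stands clearly higher, as the step of a number 0.68 log units lower from compound 1 to compound 3 (beyond the scatter) shows. Compound 4 `CC(C)CN(c1ccc(F)cc1)S(=O)(=O)c1ccc2c(c1)C(=O)CC(C1CCOCC1)O2` differs from compound 3 in one place: fluoro in place of dimethylamino on an aromatic carbon. The step of a number 0.02 log units lower from compound 2 to compound 3 (within the scatter) bears most directly on this change, and the steps of a number 0.66 log units lower from compound 1 to compound 2 (beyond the scatter) and a number 0.68 log units lower from compound 1 to compound 3 (beyond the scatter) show the two replacing groups behaving alike. Compound 2, at 3.62, carries an additional fluoro that compound 4 lacks. A small downward step is therefore expected, a number 0.15 log units lower from compound 3 to compound 4 (within the scatter), within the scatter. Compound 4 is estimated at 3.45, between 3.1 and 3.8.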

Compound 4, distribution coefficient: 3.48
For compound 4 the middle estimate is 0.03 log units below the measured one, and the stated range covers the measured number.
By their numbers in this assay, from the lowest: compounds 4, 3 and 2 (each within the scatter of the next); then compound 1.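

In this assay, the step of a number 0.12 log units lower from compound 3 to compound 4 (within the scatter) shows that fluoro and dimethylamino on this aromatic carbon cannot be told apart, and the step of a number 0.14 log units lower from compound 2 to compound 4 (within the scatter) shows the same for hydrogen and fluoro at the other substituted ring carbon. Only the 2,4-dimethylphenyl group stands apart, with the step of a number 0.80 log units lower from compound 1 to compound 4 (beyond the scatter) lying beyond the scatter. Nothing measured here explains these steps. On these data alone, whether a carboxylic acid or a nitrile in place of the fluoro of compound 4 would also stay within the scatter remains open.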